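From compound 1 to compound 4: adding a chloro group

This account rests on a few compounds, and the source may have more. Where it says the series, first, only, none or still open, it means among the compounds named here.

Measured in a functional assay on CAKI-1 cells (Homo sapiens) for inhibition, read by sulforhodamine B assay, with a stated time of 48 h; on this read-out higher numbers stand for weaker inhibition of growth and lower numbers for stronger inhibition of growth:
- Compound 1 `O=C(Nc1cccc(-n2cc(-c3ccncc3)c(-c3ccc(Cl)c(O)c3)n2)c1)Nc1cccc(C(F)(F)F)c1`: > 32500 nM, a limit of the assay
- Compound 2 `COc1cc(-c2nn(-c3cccc(NC(=O)Nc4cccc(C(F)(F)F)c4)c3)cc2-c2ccncc2)ccc1Cl`: 3510 nM
- Compound 3 `O=C(Nc1cccc(-n2cc(-c3ccncc3)c(-c3ccc(Cl)c(O)c3)n2)c1)Nc1cc(C(F)(F)F)cc(C(F)(F)F)c1`: 4420 nM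

Compound 1 stands at the limit of > 32500 nM in this assay, at which 1 of the 3 values shown sits, so it has no exact place on the scale. Compound 4 `O=C(Nc1cccc(-n2cc(-c3ccncc3)c(-c3ccc(Cl)c(O)c3)n2)c1)Nc1ccc(Cl)c(C(F)(F)F)c1` differs from it by chloro in place of hydrogen on an aromatic carbon, ortho to a trifluoromethyl group. The closest guide is an at least 7.3-fold lower number from compound 1 to compound 3 (0.86 log units; beyond the scatter), where a second trifluoromethyl group enters the same ring. A more distant guide is an at least 9.2-fold lower number from compound 1 to compound 2 (0.96 log units; beyond the scatter), which changes the other end of the molecule. As far as these compounds go, both steps lie beyond the scatter, but each starts from a limit, so its true size is unknown. A step of similar size toward a lower number, meaning stronger inhibition of growth, is therefore expected in this assay. The expected change is an at least 6.5-fold lower number from compound 1 to compound 4 (0.81 log units; beyond the scatter). For compound 4 the estimated value is 5000 nM, with an expected range of 1800 nM to 20000 nM.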

Compound 4, concentration for total growth inhibition: 2630 nM
The estimate for compound 4 lay 1.9-fold (0.28 log units) above the measured number, and the stated range covers the measured number.
By their numbers in this assay, from the lowest: compounds 4, 2 and 3 (each within the scatter of the next). At a limit, above all of these: compound 1.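

In this assay, chloro in place of hydrogen on this aromatic carbon, ortho to a trifluoromethyl group and para to a large group, gives an at least 12-fold lower number from compound 1 to compound 4 (1.09 log units; beyond the scatter). The earlier change on this ring brought in a second trifluoromethyl group, whereas this one shows that a single chlorine atom at this position is enough to give a measurable number in place of a limit. The true size of the step remains unknown because compound 1 sits at a limit: the limit of > 32500 nM in this assay, at which 1 of the 4 values shown sits.

The compounds shown leave open whether fluoro, methyl or an amine on this same carbon would give a similar number, or whether the effect is particular to chloro. They also leave open whether chloro here would still lower the number in compound 2, which carries a methyl on the oxygen.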